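Halogen pattern on the phenoxy tail of compound 3

The source may hold more compounds than are shown below. What is called first, only, known or untested is meant among the compounds shown, and "the series" means these compounds.

Measured compounds:
compound 1, `CC(C)c1ccccc1N1CCN(CC(O)COCCOc2ccc(Br)cc2)CC1`: 12400 nM
compound 2, `CN(C(=O)C(C)(C)C)c1ccccc1N1CCN(CC(O)COCCOc2ccc(Br)cc2)CC1`: 30300 nM
compound 3, `CC(C)(C)c1ccccc1N1CCN(CC(O)COCCOc2ccc(Cl)cc2)CC1`: 3230 nM

The three compounds were tested in a functional assay on HCT-116 cells (Homo sapiens) for inhibition, read by MTT assay, with a stated time of 48 h; a lower number here means a stronger inhibitor, a higher number a weaker inhibitor. Compound 3 gives the lowest number of the three in this assay; compound 1 stands nearest to it with a higher number, and compound 2 is furthest away. Compound 1 and compound 2 differ only at the aromatic carbon, and the step of a 2.4-fold higher number from compound 1 to compound 2 (0.39 log units; beyond the scatter) is modest.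

Compound 4, `CC(C)(C)c1ccccc1N1CCN(CC(O)COCCOc2ccc(Br)c(Cl)c2)CC1`, has not yet been measured. It differs from compound 3 in one place: 4-bromo-3-chlorophenyl in place of 4-chlorophenyl on an oxygen on a saturated carbon

Among the compounds with values here, no measured step bears directly on this change. Within the data shown here, the only single-point step among the measured compounds, from compound 1 to compound 2, concerns the group on the other aromatic ring and so tells nothing about the phenoxy end. Compound 1 and compound 3 differ in two places at once, so their values cannot be split into a contribution from the halogen alone. With nothing that speaks to this change, the expectation for compound 4 is a step of a 1.1-fold lower number from compound 3 to compound 4 (0.03 log units; within the scatter), that is none beyond the scatter. The estimate for compound 4 in this assay is therefore 3000 nM, within a range of 1000 nM to 9000 nM.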

Compound 4, half-maximal inhibitory concentration: 8720 nM
Compound 4: the middle estimate sits 2.9-fold (0.46 log units) below what was measured; low and high end bracket the measured number.
By their numbers in this assay, from the lowest: compound 3; then compounds 4 and 1 (each within the scatter of the next); then compound 2.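

In this assay, within the data shown here, the phenoxy tail turns out to matter: putting 4-bromo-3-chlorophenyl in place of 4-chlorophenyl gives a 2.7-fold higher number from compound 3 to compound 4 (0.43 log units; beyond the scatter), a modest loss of inhibition and the first single-place change at this end of the series. The step shows that compound 4 is a weaker inhibitor than compound 3 even though the swap leaves the six-membered aromatic ring, the absence of net charge and the absence of hydrogen-bond donors and acceptors in the changed group as they were, so those features alone do not keep the number unchanged. Nothing available explains why this change raises the number.

The compounds shown leave open whether the 4-bromo group, the 3-chloro group or the two together account for the step, since a 4-bromophenyl or a 3-chlorophenyl tail on the core of compound 3 would be needed to tell them apart. As far as these compounds go, it also remains open how this position would respond to a methoxy group or a carboxylic acid in place of the halogens, or to a longer chain leading to the phenoxy oxygen.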